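Dropping the Nitro Group from a Weakly Active Biphenyl Phenol

The source may report more compounds than this note shows. Statements on the series, on what has been measured and on what is new or still open speak of the compounds shown alone.

Compound 3 `C=CCc1cc(-c2cccc([N+](=O)[O-])c2)ccc1O` sits at the weak end of the three compounds measured in a functional assay on HUVEC cells (Homo sapiens) for antiproliferative activity, read by MTT assay, with a stated time of 24 h; on this read-out lower numbers stand for stronger inhibition and higher numbers for weaker inhibition. In this assay compound 3 gives only a limit, > 100000 nM. Compound 1 `C=CCc1cc(-c2cccc(C(F)(F)F)c2)ccc1O` gives 76000 nM, so an at least 1.3-fold higher number from compound 1 to compound 3 (0.11 log units; that floor lies within the scatter). Compound 2 `C=CCc1cc(-c2cccc([N+](=O)[O-])c2)ccc1OC` likewise gives only a limit, > 100000 nM. For that reason a step that the two limits leave unreadable from compound 2 to compound 3, and the limit of > 100000 nM in this assay, at which 2 of the 3 values shown sit, is all the two share. Compound 4 `C=CCc1cc(-c2ccccc2)ccc1O` differs from compound 3 by hydrogen in place of nitro on an aromatic carbon. Going by the values given here, no measured step removes a substituent entirely, and the only readable number comes from compound 1 at 76000 nM, so no step beyond the scatter is expected in this assay. Compound 4 is estimated at 100000 nM, with a range from 40000 nM to 250000 nM. That estimate means an expected step of a number no higher from compound 3 to compound 4 (the limit leaves the size open).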

Compound 4, half-maximal inhibitory concentration: > 100000 nM
Compound 4 gave a limit, no number; the forecaster's own chance of this, stated with the estimate: 55%; the middle value lies on the limit itself.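

With hydrogen at this position, compound 4 also gives only a limit in this assay, so the step from nitro to hydrogen cannot be read, and removing the substituent brings no readable value. Going by these compounds alone, the one readable comparison is an at least 1.3-fold higher number from compound 1 to compound 4 (0.11 log units; that floor lies within the scatter), so hydrogen and trifluoromethyl are not separated beyond the scatter. The series now crowds at the assay's limit: the limit of > 100000 nM in this assay, at which 3 of the 4 values shown sit.

On these data alone, whether an amine or a carboxylic acid at this position would give a readable value stays open. So does whether any group here could move the shared core clearly away from that limit.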